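The source may hold more compounds than are shown below. What is called first, only, known or untested is meant among the compounds shown, and "the series" means these compounds.

Compound 1, with the structure `Cc1ccccc1C(=O)/C=C1\Nc2ccccc2OC1=O`, is tested in an ADME assay on Vero cells (Chlorocebus sabaeus) for cytotoxicity, read by MTT assay, with a stated time of 72 h; on this read-out lower numbers stand for higher toxicity in this test and higher numbers for lower toxicity in this test. In this assay compound 1 reaches only a limit of the test, > 1790000 nM, as captured by the limit of > 1790000 nM in this assay, at which 1 of the 2 values shown sits. For the measured compounds named here, compound 2, with the structure `O=C1Oc2ccccc2N/C1=C\C(=O)c1ccccc1Cl`, gives in this assay 1570000 nM, and it stands as the only numerical value shown. Between these two compounds the change is a chloro in place of a methyl on an aromatic carbon, giving a step of an at least 1.1-fold lower number from compound 1 to compound 2 (0.05 log units; that floor lies within the scatter), which is a floor rather than a number.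

Compound 3, with the structure `COC(=O)/C=C1\Nc2ccccc2OC1=O`, differs from compound 2 by methoxy in place of 2-chlorophenyl on a carbonyl carbon: a methoxy in place of 2-chlorophenyl on a carbonyl carbon. Going by the values given here, only the step from compound 1 to compound 2 is known, and it sits within the scatter, so no step beyond the scatter is expected in this assay for compound 3, namely a 1.0-fold higher number from compound 2 to compound 3 (0.01 log units; within the scatter). Compound 3 is therefore estimated at 1600000 nM, with an expected range from 500000 nM to 3500000 nM.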

Compound 3, half-maximal cytotoxic concentration: > 2280000 nM
Compound 3 was reported as a limit; the forecaster's own chance of this, stated with the estimate: 50%; middle value at least 1.4-fold (0.15 log units) away from the limit.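

Swapping the whole 2-chlorophenyl group on the carbonyl carbon for the much smaller methoxy brings no sign of greater toxicity in this assay, with an at least 1.4-fold higher number from compound 2 to compound 3 (0.16 log units; that floor lies within the scatter). The earlier pair differed only by one group on that aromatic ring, whereas here the ring itself leaves, so compound 3 shows that this ring is not needed for the low toxicity seen in this series. The step from compound 1 to compound 3 cannot be read, and compound 3 gives a limit and not a number: the limit of > 2280000 nM in this assay, at which 1 of the 3 values shown sits.

As far as these compounds go, it remains open whether an amine or an ethoxy group on the same carbonyl carbon would keep toxicity this low in this assay. With two of the three results being limits, the true size of any difference among these compounds also remains open.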